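The source may hold more compounds than are shown below. What is called first, only, known or untested is meant among the compounds shown, and "the series" means these compounds.

Series notes. Compound 1 `COc1ccccc1C1C(C#N)=C(N)N(c2cc(OC)c(OC)c(OC)c2)C2=C1C(=O)CC(C)(C)C2` gives 30% in a functional assay on Ehrlich cells (Mus musculus) for cytotoxicity, tested at 10 ug/mL; on this read-out higher numbers stand for a stronger effect at the one concentration tested and lower numbers for a weaker effect. Compound 2 `COc1cc(N2C(N)=C(C#N)C(c3ccc([N+](=O)[O-])cc3)C3=C2CC(C)(C)CC3=O)cc(OC)c1OC` gives 10% in this assay, and compound 3 `COc1cc(N2C(N)=C(C#N)C(c3ccccc3Cl)C3=C2CC(C)(C)CC3=O)cc(OC)c1OC` gives 10%. The step of a number 20 percentage points lower from compound 1 to compound 2 (beyond the scatter) and the step of a number 20 percentage points lower from compound 1 to compound 3 (beyond the scatter) run in the same direction, whereas no change at the digits printed from compound 2 to compound 3 (within the scatter). Compound 2 thus stands level with compound 3 at the digits shown, the two together at the low end of the three numbers; compound 1 is the furthest from compound 2, a modest step higher and beyond the scatter.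

Compound 4 `COc1cc(N2C(N)=C(C#N)C(c3ccc(C)o3)C3=C2CC(C)(C)CC3=O)cc(OC)c1OC` has not yet been measured. Its difference from compound 2 is this: 5-methylfuran-2-yl in place of 4-nitrophenyl on a saturated ring carbon. Among the measured compounds shown here, two measured steps concern a change at the same saturated ring carbon: a number 20 percentage points lower from compound 1 to compound 2 (beyond the scatter), a modest step beyond the scatter, and no change at the digits printed from compound 2 to compound 3 (within the scatter), a step within it. Neither step involved a five-membered aromatic ring with one hetero atom, so the evidence for this particular change is thin. On these two steps a change near the scatter is expected in this assay, with a modest step upward not excluded; the expected step is a number 5 percentage points higher from compound 2 to compound 4 (within the scatter). Compound 4 is accordingly estimated at 15%, with a range from 0% to 35%.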

Compound 4, a percentage reported as activity, at one concentration (the size of the read-out at that concentration, not a potency): 21%
For compound 4 the middle estimate is 6 percentage points below the measured one; low and high end bracket the measured number.
By their numbers in this assay, from the lowest: compounds 2 and 3 (each within the scatter of the next); then compounds 4 and 1 (each within the scatter of the next).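

Among the compounds shown here, at this saturated ring carbon, 5-methylfuran-2-yl is the first five-membered aromatic ring with 1 hetero atom, and in this assay it stands apart from both 4-nitrophenyl, with a number 11 percentage points higher from compound 2 to compound 4 (beyond the scatter), and 2-chlorophenyl, with a number 11 percentage points higher from compound 3 to compound 4 (beyond the scatter). With 2-methoxyphenyl the comparison gives a number 9 percentage points lower from compound 1 to compound 4 (within the scatter), so among these four compounds a six-membered aromatic ring of carbon only at this position is not needed to reach the level of compound 1, and ring size alone does not sort the series: compounds 1, 2 and 3 all carry such a ring, yet compound 1 stands apart from compounds 2 and 3. No measurement at hand accounts for these differences.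

The compounds shown leave open how a thiophen-2-yl, a pyridyl or a cyclohexyl group would read at this carbon, and whether the methyl on the furan ring matters, as an unsubstituted furan-2-yl group is not among them. As far as these compounds go, the 3,4,5-trimethoxyphenyl group on the ring nitrogen is common to all four compounds, so the effect of replacing it, for instance with a phenyl ring bearing a carboxylic acid, also remains open.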